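This account rests on a few compounds, and the source may have more. Where it says the series, first, only, none or still open, it means among the compounds named here.

Of the compounds shown here, three sharing one core have been measured in a functional assay on MCF7 cells (Homo sapiens) for inhibition, read by fluorescence, with a stated time of 72 h; a lower number here means a stronger inhibitor of growth, a higher number a weaker inhibitor of growth. Compound 2 `CCCCCCn1cnc2c(Nc3ccc(Cl)cc3)nc(N[C@H]3CC[C@H](N)CC3)nc21` gives 4200 nM in this assay. Compound 1 `CC(C)CCn1cnc2c(Nc3ccc(Cl)cc3)nc(N[C@H]3CC[C@H](N)CC3)nc21` differs from compound 2 by a single change, (isopropyl in place of butyl on a saturated chain carbon, two bonds along the chain from an aromatic nitrogen), and in this assay compound 1 gives 2700 nM. That change gave a 1.6-fold lower number from compound 2 to compound 1 (0.19 log units; within the scatter). Compound 3 `CCCCCCn1cnc2c(Nc3cccc(Cl)c3)nc(N[C@H]3CC[C@H](N)CC3)nc21` differs from compound 2 at the other end of the molecule, and in this assay compound 3 gives 2700 nM. That change gave a 1.6-fold lower number from compound 2 to compound 3 (0.19 log units; within the scatter). The values of compound 1 and compound 3 fall within the usual scatter of each other, so nothing separates them.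

Compound 4 `CC(C)CCn1cnc2c(Nc3cccc(Cl)c3)nc(N[C@H]3CC[C@H](N)CC3)nc21` has not yet been measured in this assay. It differs from compound 3 by isopropyl in place of butyl on a saturated chain carbon, two bonds along the chain from an aromatic nitrogen. This is the same change that takes compound 2 to compound 1, at the same place, and it occurs twice among these four compounds. The cores on which the change is made, those of compound 2 and compound 3, differ by 3-chlorophenyl in place of 4-chlorophenyl on a nitrogen on an aromatic ring.

The step expected in this assay is a 1.4-fold lower number from compound 3 to compound 4 (0.15 log units; within the scatter), because the same change in the earlier pair gave a 1.6-fold lower number from compound 2 to compound 1 (0.19 log units; within the scatter), a step that stayed within the scatter. Compound 4 is estimated at 1900 nM in this assay. For compound 4 the expected range runs from 900 nM to 4000 nM.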

Compound 4, concentration for 50% growth inhibition: 2100 nM
Estimate against measurement, compound 4: 1.1-fold (0.04 log units) below; low and high end bracket the measured number.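

In this assay, isopropyl in place of butyl on the saturated chain gave a 1.3-fold lower number from compound 3 to compound 4 (0.11 log units; within the scatter), which can be set beside the same change on the other core: the same change on two cores in this assay, a 1.6-fold lower number (0.19 log units; within the scatter) from compound 2 to compound 1 and a 1.3-fold lower number (0.11 log units; within the scatter) from compound 3 to compound 4, 1.2-fold (0.08 log units) apart, within the scatter of two such steps. The swap at the other end of the molecule, 3-chlorophenyl in place of 4-chlorophenyl, gave a 1.3-fold lower number from compound 1 to compound 4 (0.11 log units; within the scatter), and it too can be compared across two cores: the same change on two cores in this assay, a 1.6-fold lower number (0.19 log units; within the scatter) from compound 2 to compound 3 and a 1.3-fold lower number (0.11 log units; within the scatter) from compound 1 to compound 4, 1.2-fold (0.08 log units) apart, within the scatter of two such steps. Among these compounds, both changes therefore behave alike on the two cores tested, but every step here lies within the scatter, so this agreement shows only that neither change moved the number measurably on either core, not that a change with a real effect would carry over in the same way.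

The four compounds leave open whether any change at these two places can move growth inhibition beyond the scatter, and so whether a real effect at one end would hold up when the other end is altered. A much shorter chain such as ethyl, a chain ending in a hydroxyl group or an amine, or a phenyl ring bearing fluorine or methoxy in place of chlorine would test this on wider ground.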